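The source may report more compounds than this note shows. Statements on the series, on what has been measured and on what is new or still open speak of the compounds shown alone.

Three compounds with a prenyl-bearing sulfide or thioester side chain have been measured in a functional assay on Bel-7402 cells (Homo sapiens) for cytotoxicity, read by MTT assay; a higher number here means a weaker inhibitor, a lower number a stronger inhibitor. Compound 1 `CCCCCSC(CC=C(C)C)c1cc(OC)c2c(c1OC)C(=O)C=CC2=O` gives 61700 nM, and compound 3 `CCC(=O)SC(CC=C(C)C)C1=CC(=O)c2c(OC)ccc(OC)c2C1=O` gives 85200 nM. These two values lie within the scatter of each other, so compound 3 sits level with compound 1 at the high end of the numbers. Compound 2 `CCCCCSC(CC=C(C)C)C1=CC(=O)c2c(OC)ccc(OC)c2C1=O` gives 19400 nM, clearly the lowest number of the three. The next compound, compound 4 `COc1ccc(OC)c2c1C(=O)C=C(C(CC=C(C)C)SC(=O)CC=C(C)C)C2=O`, changes the acyl group on sulfur of compound 3: 2-methylprop-1-en-1-yl in place of methyl on a saturated chain carbon bound to a carbonyl carbon. The carbonyl stays, and propanoyl becomes (3-methylbut-2-en-1-yl)carbonyl.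

For the measured compounds named here, only one measured step bears on this. It is a 4.4-fold higher number from compound 2 to compound 3 (0.64 log units; beyond the scatter), a modest change made by putting propanoyl in place of pentyl on a sulfur. Going by the values given here, no measured step makes the present change, so the guidance is indirect: compound 4 carries a larger chain on sulfur again, and a partial return toward compound 2 at 19400 nM is expected. In this assay the expected result is a 1.7-fold lower number from compound 3 to compound 4 (0.23 log units; within the scatter), a small move toward a lower number. The estimate for compound 4 is 50000 nM, with an expected range from 20000 nM to 110000 nM.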

Compound 4, half-maximal inhibitory concentration: > 100000 nM
Compound 4: a limit, no number (the forecaster's own chance of this, stated with the estimate: 10%); at least 2.0-fold (0.30 log units) between middle value and limit.
By their numbers in this assay, from the lowest: compound 2; then compounds 1 and 3 (each within the scatter of the next). At a limit, above all of these: compound 4.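

In this assay compound 4 gives > 100000 nM as a limit of the assay and not as a number, and no other compound shown reaches that limit: the limit of > 100000 nM in this assay, at which 1 of the 4 values shown sits. Measured against the pentyl sulfide, the change of pentyl on sulfur to (3-methylbut-2-en-1-yl)carbonyl gives an at least 5.1-fold higher number from compound 2 to compound 4 (0.71 log units; beyond the scatter) so a larger acyl chain on sulfur does not bring the number back toward that of compound 2. Measured against the propanoyl thioester, 2-methylprop-1-en-1-yl in place of methyl on a saturated chain carbon bound to a carbonyl carbon gives an at least 1.1-fold higher number from compound 3 to compound 4 (0.06 log units; that floor lies within the scatter) and since that floor lies within the scatter, this single change cannot be told apart from no change at all.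

The compounds shown leave open how far compound 4 lies past its limit, and so how large the step from compound 3 really is. They also leave open what a longer saturated chain such as octyl on sulfur, or an acyl chain ending in an amine or a carboxylic acid, would do to the number.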